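A few compounds are considered here, and "the series" means these few. Any claim that something is new, unique, unknown or untested is made for them only; others in the source may bear on it.

Measured so far:
- compound 1 `COc1cc(C)cc(-c2nn(CC#N)cc2-c2ccc(-c3cccc(C(C)=O)c3)nc2)c1`: compound 1 gives 94% in a functional assay on MDA-MB-435 cells (Homo sapiens) for cytotoxicity, read by sulforhodamine B assay, with a stated time of 48 h, tested at 0.01 uM; a higher number here means a weaker effect of the compound at the concentration tested, a lower number a stronger effect
- compound 2 `Cc1cc(O)cc(-c2nn(CC#N)cc2-c2ccnc(-c3ccc(Oc4ccccc4)cc3)c2)c1`: compound 2 gives 95% in this assay
- compound 3 `COc1cc(C)cc(-c2nn(CC#N)cc2-c2ccnc(-c3ccc(N(C)C)cc3)c2)c1`: compound 3 gives 94% in this assay

Compound 3 stands level with compound 1 at the digits shown, and the two together hold the lowest of the three numbers; compound 2 lies within the scatter of both. For the measured compounds named here, all three values sit within the usual scatter of one another, so no compound can be called stronger or weaker than the rest.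

Compound 4 `Cc1cc(O)cc(-c2nn(CC#N)cc2-c2ccnc(-c3ccc(N(C)C)cc3)c2)c1` has not yet been measured. It differs from compound 3 in one place: hydrogen in place of methyl on an oxygen on an aromatic ring. Going by the values given here, no step between measured compounds isolates this change. Compound 2 also carries a hydroxy group and its value in this assay lies within the scatter of compound 3, so a step no larger than the scatter is expected, no change at the digits printed from compound 3 to compound 4 (within the scatter). Compound 4 is therefore estimated at 94%, with a range from 85% to 101%.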

Compound 4, a percentage reported as activity, at one concentration (the size of the read-out at that concentration, not a potency): 91%
The estimate for compound 4 lay 3 percentage points above the measured number; measured number inside the range.
By their numbers in this assay, from the lowest: compounds 4, 1, 3 and 2 (each within the scatter of the next).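

Methoxy to hydroxy on the aromatic ring gives a number 3 percentage points lower from compound 3 to compound 4 (within the scatter) in this assay and so, with dimethylamino on the other side of the molecule, this swap cannot be told apart from no change. Dimethylamino in place of phenoxy, with the hydroxy group kept, gives a number 4 percentage points lower from compound 2 to compound 4 (within the scatter) and so also stays inside the usual scatter. No other measurement here bears on why these steps are so small. Still open, on these data alone, is whether ethoxy or benzyloxy on that oxygen, or a carboxylic acid in place of the hydroxy group, would move the number beyond the scatter.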